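The source may report more compounds than this note shows. Statements on the series, on what has been measured and on what is new or still open speak of the compounds shown alone.

Measured so far in an assay on cell membranes for binding affinity to Equilibrative nucleoside transporter 1 (Homo sapiens); a higher number here means a weaker inhibitor, a lower number a stronger inhibitor:
compound 1 `CCCNc1nc2c(SCc3ccccc3)ncnc2n1C1O[C@H](CO)[C@@H](O)[C@H]1O` gives 5.3 nM
compound 2 `CCCCCNc1nc2c(SCc3ccccc3)ncnc2n1C1O[C@H](CO)[C@@H](O)[C@H]1O` gives 2.3 nM

Among the measured compounds shown here, compound 2 holds the lower of the two numbers, and the one step connecting the pair, a 2.3-fold lower number from compound 1 to compound 2 (0.36 log units; beyond the scatter), puts it at the stronger end, with compound 1 as its only neighbour.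

Compound 3 `CCCCCCNc1nc2c(SCc3ccccc3)ncnc2n1C1O[C@H](CO)[C@@H](O)[C@H]1O` has not yet been measured. It differs from compound 2 by methyl in place of hydrogen on a saturated chain carbon, five bonds along the chain from a nitrogen on an aromatic ring, so the same chain grows by one carbon. For the measured compounds named here, the only step that bears on this change is a 2.3-fold lower number from compound 1 to compound 2 (0.36 log units; beyond the scatter), which came from growing that chain by two carbons. One more carbon is a smaller change in the same direction, so the step from compound 2 to compound 3 is expected to be small, at most a slight fall, roughly a 1.3-fold lower number from compound 2 to compound 3 (0.11 log units; within the scatter). Compound 3 is therefore estimated at about 1.8 nM, most likely between 0.9 nM and 3.6 nM.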

Compound 3, inhibition constant: 3.7 nM
Compound 3: the middle estimate sits 2.1-fold (0.31 log units) below what was measured; the measured number lies above the stated range.
By their numbers in this assay, from the lowest: compounds 2, 3 and 1 (each within the scatter of the next, the first and the last beyond it).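

In this assay, the gain seen on the earlier lengthening of the chain does not carry on, since adding one more carbon gives a 1.6-fold higher number from compound 2 to compound 3 (0.21 log units; within the scatter). Set against the shortest chain, the longest gives a 1.4-fold lower number from compound 1 to compound 3 (0.16 log units; within the scatter), so it cannot be told apart from either of the shorter chains, even though those two do differ from each other; this position accepts the longer chain without a clear gain or loss. Nothing available explains why the added carbon brought no further gain.

Still open, as far as these compounds go, is whether a yet longer straight chain would keep the number in this range or finally move it. Also open, from the compounds shown here alone, is how a branched chain, a cyclohexyl ring or a chain ending in an amine or a carboxylic acid would behave at this position.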